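Swapping the Aryl Group on the Ring Nitrogen

The source may hold more compounds than are shown below. What is called first, only, known or untested is meant among the compounds shown, and "the series" means these compounds.

Compound 1 `Cc1nc(-c2ccccc2)c(C(=O)N2CCN(c3ccc(Cl)c(Cl)c3)CC2)o1`: 124 nM
Compound 2 `Cc1nc(-c2ccccc2)c(C(=O)N2CCN(c3cccc(C#N)c3)CC2)o1`: 39.6 nM
Compound 3 `Cc1nc(-c2cccc(F)c2)c(C(=O)N2CCN(c3cc(Cl)cc(Cl)c3)CC2)o1`: 41.7 nM

Of the compounds shown here, three have been measured in a functional assay on HL-60 cells (Homo sapiens) for inhibition, read by MTT assay, with a stated time of 72 h; a higher number here means a weaker inhibitor, a lower number a stronger inhibitor. Compound 2 gives the lowest number of the three; compound 3 sits within the scatter of it, while compound 1 lies well above. Going by the values given here, the one single-point step recorded, a 3.1-fold lower number from compound 1 to compound 2 (0.50 log units; beyond the scatter), shows a modest gain on exchanging the aryl group on the ring nitrogen.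

Compound 4 `CC(=O)c1ccc(N2CCN(C(=O)c3oc(C)nc3-c3ccccc3)CC2)cc1` has not been measured. It differs from compound 2 in one place: 4-acetylphenyl in place of 3-cyanophenyl on an amine nitrogen in a ring. Among the compounds with values here, no measured step exchanges a cyano-bearing aryl for an acetyl-bearing one, so the step from compound 1 to compound 2 is the only guide, and it only says that this position tolerates a change of aryl group within a modest range. With one acceptor leaving and one entering, the expected step of a 1.5-fold higher number from compound 2 to compound 4 (0.18 log units; within the scatter) is small, and it is estimated that compound 4 will land near compound 2, at 60 nM with a range from 20 nM to 180 nM.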

Compound 4, half-maximal inhibitory concentration: "not active" (no number reported)
The entry for compound 4 holds no number, and the estimate cannot be compared.
By their numbers in this assay, from the lowest: compounds 2 and 3 (each within the scatter of the next); then compound 1.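

Going by these compounds alone, compound 4 is reported as "not active" with no number, so no step from compound 2 to compound 4 can be read, and no evidence bears on this result. The compounds shown leave open how the 4-acetylphenyl group compares numerically with the 3-cyanophenyl group.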